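Third methoxy on compound 1: expected effect

This account rests on a few compounds, and the source may have more. Where it says the series, first, only, none or still open, it means among the compounds named here.

Compound 1 `COc1ccc(C(=O)/C=C/c2cc(-c3cc(OC)c(OC)c(OC)c3)n[nH]2)cc1OC` stands highest of the two numbers in hand: in a functional assay on MCF7 cells (Homo sapiens) for cytotoxicity, read by sulforhodamine B assay, with a stated time of 48 h, tested at 100 uM (a lower number here means a stronger effect, a higher number a weaker effect of the compound at the concentration tested), compound 1 gives -66%, and its nearest neighbour, compound 2 `COc1ccc(C(=O)/C=C/c2cc(-c3cc(OC)c(OC)c(OC)c3)n[nH]2)cc1`, gives -69% in this assay. Among the compounds with values here, the single measured step, a number 3 percentage points lower from compound 1 to compound 2 (within the scatter), came with hydrogen in place of methoxy on an aromatic carbon and did not leave the scatter. Compound 3 `COc1cc(C(=O)/C=C/c2cc(-c3cc(OC)c(OC)c(OC)c3)n[nH]2)cc(OC)c1OC` differs from compound 1 by methoxy in place of hydrogen on an aromatic carbon. This is the opposite kind of change from the measured one, a number 3 percentage points lower from compound 1 to compound 2 (within the scatter), which stayed within the scatter; nothing else in hand bears on the new position. The expectation is therefore no step beyond the scatter, an estimated a number 1 percentage points higher from compound 1 to compound 3 (within the scatter) in this assay. Compound 3 is estimated at -65% in this assay, with a range from -82% to -45%.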

Compound 3, a percentage reported as activity, at one concentration (the size of the read-out at that concentration, not a potency): -72%
For compound 3 the middle estimate is 7 percentage points above the measured one; the range from low to high includes it.
By their numbers in this assay, from the lowest: compounds 3, 2 and 1 (each within the scatter of the next).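

In this assay the methoxy entering ortho to a methoxy group and meta to a large group gives a number 6 percentage points lower from compound 1 to compound 3 (within the scatter), so this position takes the group without a step beyond the scatter. The earlier step, a number 3 percentage points lower from compound 1 to compound 2 (within the scatter), covered only the loss of a methoxy from this ring; gain and loss of a methoxy on this ring now both stay within the scatter across these three compounds. No measurement in hand offers an explanation for the size of either step.

From the compounds shown here alone, only hydrogen and methoxy have been compared on this ring, so it remains open whether an amine, a carboxylic acid or a longer alkoxy chain at this position would move the read-out beyond the scatter. A percentage at a single concentration also shows only the size of the effect at that concentration and leaves open whether these compounds would show a stronger or weaker effect relative to one another at any other concentration.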